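Aryl variation on the triazole nitrogen: compound 4

This account rests on a few compounds, and the source may have more. Where it says the series, first, only, none or still open, it means among the compounds named here.

Compound 3 `CCc1cccc(C)c1-n1nncc1CN1C(=O)C2(C(C#N)=C(N)Oc3c(N)cc4nc5ccccc5nc4c32)c2ccccc21` is the closest measured neighbour of compound 4 `Cc1cc(C)c(-n2nncc2CN2C(=O)C3(C(C#N)=C(N)Oc4c(N)cc5nc6ccccc6nc5c43)c3ccccc32)c(C)c1`. In a functional assay on HepG2 cells (Homo sapiens) for antiproliferative activity, read by MTT assay, with a stated time of 48 h (a lower number here means a stronger inhibitor, a higher number a weaker inhibitor), compound 3 gives > 50000 nM, which is a limit of the assay and not a number. Compound 1 `Cc1ccccc1-n1nncc1CN1C(=O)C2(C(C#N)=C(N)Oc3c(N)cc4nc5ccccc5nc4c32)c2ccccc21` in this assay gives > 50000 nM, again a limit. Compound 2 `COc1ccc(-n2nncc2CN2C(=O)C3(C(C#N)=C(N)Oc4c(N)cc5nc6ccccc6nc5c43)c3ccccc32)cc1` in this assay gives > 50000 nM, also a limit. The steps a step that the two limits leave unreadable from compound 1 to compound 2, a step that the two limits leave unreadable from compound 1 to compound 3 and a step that the two limits leave unreadable from compound 2 to compound 3 are all unreadable, since (the limit of > 50000 nM in this assay, at which 3 of the 3 values shown sit). The change to compound 4 is 2,4,6-trimethylphenyl in place of 2-ethyl-6-methylphenyl on an aromatic nitrogen. Among the measured compounds shown here, no measured step bears readably on it, so for compound 4 nothing beyond a further limit is expected in this assay, and a step that the limit leaves unreadable from compound 3 to compound 4 is the expected step. Compound 4 is expected to give 80000 nM, between 20000 nM and 300000 nM.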

Compound 4, half-maximal inhibitory concentration: 48100 nM
The estimate for compound 4 lay 1.7-fold (0.22 log units) above the measured number; the measured number falls inside the stated range.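

In this assay, compound 4 is the only compound shown with a number rather than a limit, so 2,4,6-trimethylphenyl on the aromatic nitrogen gives the first readable value at this position. Even so, the steps are only floors within the scatter: an at least 1.0-fold lower number from compound 3 to compound 4 (0.01 log units; that floor lies within the scatter), an at least 1.0-fold lower number from compound 2 to compound 4 (0.01 log units; that floor lies within the scatter) and an at least 1.0-fold lower number from compound 1 to compound 4 (0.01 log units; that floor lies within the scatter). The steps among the other compounds cannot be read, and the limit still governs most of the set: the limit of > 50000 nM in this assay, at which 3 of the 4 values shown sit.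

Open, as far as these compounds go, is how an aryl group bearing an amine or a carboxylic acid would read in this assay. Also open, from the compounds shown here alone, is whether any group on this nitrogen gives a step from compound 4 beyond the scatter.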